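Chloro in place of methyl: compound 2 to compound 3

The source may report more compounds than this note shows. Statements on the series, on what has been measured and on what is new or still open speak of the compounds shown alone.

In a functional assay on SK-N-SH cells (Homo sapiens) for cytotoxicity, read by MTT assay, with a stated time of 48 h (on this read-out lower numbers stand for stronger inhibition and higher numbers for weaker inhibition), compound 1 `COc1cc(/C=C/c2ccc(C)cc2)c(-c2ccccc2)c(OC)c1OC` gives 31000 nM, and compound 2 `C=C(c1ccc(C)cc1)c1cc(OC)c(OC)c(OC)c1-c1ccccc1` gives 31000 nM, so the two stand level. Among the compounds with values here, the one measured step shows no change at the digits printed from compound 1 to compound 2 (within the scatter), with 1-(4-methylphenyl)ethenyl in place of 2-(4-methylphenyl)ethenyl. Compound 3 `C=C(c1ccc(Cl)cc1)c1cc(OC)c(OC)c(OC)c1-c1ccccc1` has chloro in place of methyl on an aromatic carbon, para to a large group: chloro in place of methyl on an aromatic carbon. Within the data shown here, no measured step tests this change directly, so no shift beyond the scatter is expected in this assay, and either direction remains open. The expected outcome is a 1.1-fold lower number from compound 2 to compound 3 (0.06 log units; within the scatter). Compound 3 is estimated at 27000 nM, with an expected range of 11000 nM to 65000 nM.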

Compound 3, half-maximal inhibitory concentration: 25000 nM
For compound 3 the middle estimate is 1.1-fold (0.03 log units) above the measured one; the measured number falls inside the stated range.
By their numbers in this assay, from the lowest: compounds 3, 1 and 2 (each within the scatter of the next).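

In this assay, swapping methyl for chloro on the aromatic carbon para to a large group gives a 1.2-fold lower number from compound 2 to compound 3 (0.09 log units; within the scatter) and so does not separate these two groups at this position. Taking the 1-(4-chlorophenyl)ethenyl group together with the earlier shift of the aryl group gives a 1.2-fold lower number from compound 1 to compound 3 (0.09 log units; within the scatter) and likewise leaves the compounds level. No evidence on hand bears on this result.

Open, on these data alone, is whether a group of another kind at this place, such as an amine or a carboxylic acid, would move the number beyond the scatter. Also open, as far as these compounds go, is whether a longer chain in place of chloro would do so.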